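Methoxy Added to Compound 1: Expected Cytotoxicity

The source may report more compounds than this note shows. Statements on the series, on what has been measured and on what is new or still open speak of the compounds shown alone.

Compound 1 `O=c1ccoc2cc(OCc3cn(Cc4ccccc4)nn3)ccc12` was tested in a functional assay on HeLa cells (Homo sapiens) for cytotoxicity, read by MTT assay, with a stated time of 48 h; a lower number here means a stronger inhibitor, a higher number a weaker inhibitor. In this assay compound 1 gives > 100000 nM, which is a limit of the assay rather than a number. Compound 2 `O=c1ccoc2cc(OCc3cn(Cc4ccc(Br)cc4)nn3)ccc12` likewise gives only a limit, > 100000 nM. Compound 3 `O=c1ccoc2cc(OCc3cn(Cc4ccccc4F)nn3)ccc12` also gives only a limit, > 100000 nM. All three values sit at the limit of > 100000 nM in this assay, at which 3 of the 3 values shown sit, so the steps a step that the two limits leave unreadable from compound 1 to compound 2, a step that the two limits leave unreadable from compound 1 to compound 3 and a step that the two limits leave unreadable from compound 2 to compound 3 cannot be sized. Compound 4 `COc1ccc(Cn2cc(COc3ccc4c(=O)ccoc4c3)nn2)cc1` differs from compound 1 by methoxy in place of hydrogen on an aromatic carbon. The earlier substitutions on the same benzyl ring left every value at the limit, and nothing here points another way. Compound 4 is therefore expected to stay at the limit as well, with a step that the limit leaves unreadable from compound 1 to compound 4 too small to read. Compound 4 is estimated at 150000 nM, between 50000 nM and 500000 nM.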

Compound 4, half-maximal inhibitory concentration: 14400 nM
Compound 4: middle estimate off by 10-fold (1.02 log units), on the high side; the measured number lies below the stated range.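

In this assay, the ring carbon para to a large group on the benzyl ring turns out to be able to shift the value, as methoxy gives an at least 6.9-fold lower number from compound 1 to compound 4 (0.84 log units; beyond the scatter). The group placed there matters, with an at least 6.9-fold lower number from compound 2 to compound 4 (0.84 log units; beyond the scatter), and a similar result appears against the fluoro compound, with an at least 6.9-fold lower number from compound 3 to compound 4 (0.84 log units; beyond the scatter). Each step is only a minimum, and those among compounds 1, 2 and 3 cannot be read, because these three sit at a limit: the limit of > 100000 nM in this assay, at which 3 of the 4 values shown sit.

The compounds shown leave open how an ethoxy, a hydroxyl or an amine would compare at this position. On these data alone, whether methoxy on another ring carbon would do the same also stays open.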